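Working notes: a 2-fluorophenyl swap in a small series

The compounds below may be only part of what the source reports. "The series", "measured", "known", "first", "only" and "open" are said of these compounds alone.

In a toxicity assay on cells (Macrophage, Mus musculus, strain BALB/c) for cytotoxicity, read by MTT assay (on this read-out higher numbers stand for weaker inhibition and lower numbers for stronger inhibition), compound 1 (`C=CCOc1cc(/C=C/C(=O)c2c(O)cc(O)cc2OC)cc(OCC=C)c1Br`) gives 11500 nM. Compound 2 (`C=CCOc1cc(OC)c(C(=O)/C=C/c2cccc(OC)c2)c(OCC=C)c1`) gives 13100 nM, which lies within the usual scatter of the number for compound 1, so the two cannot be told apart on this read-out.

Compound 3 (`C=CCOc1cc(OC)c(C(=O)/C=C/c2ccccc2F)c(OCC=C)c1`) has not yet been measured. It carries 2-fluorophenyl in place of 3-methoxyphenyl on a double-bonded chain carbon bound to a double-bonded chain carbon.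

Among the measured compounds shown here, no measured pair differs in one place only, so the data give no direct size for a change of this kind. In this assay no step beyond the scatter is expected, and neither direction is favoured. The estimated 1.1-fold lower number from compound 2 to compound 3 (0.04 log units; within the scatter) is correspondingly small. For the measured compounds named here, this expectation takes compound 2 at 13100 nM as its starting point, and the range is kept wide since no single-place step has been measured. For compound 3 the estimated value is 12000 nM, with an expected range of 4500 nM to 32000 nM.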

Compound 3, half-maximal inhibitory concentration: 13300 nM
The estimate for compound 3 lay 1.1-fold (0.04 log units) below the measured number; the range from low to high includes it.
By their numbers in this assay, from the lowest: compounds 1, 2 and 3 (each within the scatter of the next).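

In this assay, among the compounds shown here, 2-fluorophenyl in place of 3-methoxyphenyl on a double-bonded chain carbon bound to a double-bonded chain carbon gives a 1.0-fold higher number from compound 2 to compound 3 (0.01 log units; within the scatter) as the first single-place comparison. The earlier compounds shown here gave no size for any such change; this pair shows that, on this read-out, the exchange at this place leaves no step that can be told from the scatter, even though 3-methoxyphenyl brings a hydrogen-bond acceptor and 2-fluorophenyl brings none. No measured property bears on why the two groups read alike.

A single exchange between two substituted phenyl groups says nothing about how far this place tolerates other kinds of group, such as an amine or a carboxylic acid on the phenyl ring, or a longer chain in its stead. As far as these compounds go, whether the same exchange would also stay within the scatter on the core of compound 1 remains open.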